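Alkyne for alkene on the sulfur-bound chain

The compounds below may be only part of what the source reports. "The series", "measured", "known", "first", "only" and "open" are said of these compounds alone.

The measured compounds:
compound 1, `C=CCSC[C@H](NC(=O)c1cc(O)c(O)c(O)c1)C(=O)OC`, in an assay on RAW264.7 cells for antagonist activity at Toll-like receptor 2 (Mus musculus), read by Griess assay, with a stated time of 24 h; a lower number here means a stronger inhibitor, a higher number a weaker inhibitor: 52100 nM
compound 2, `C=CCCCSC[C@H](NC(=O)c1cc(O)c(O)c(O)c1)C(=O)OC`, in this assay: 39200 nM

Both compounds share the same core and differ only in the chain on the saturated carbon bound to sulfur. Compound 2 gives a number that sits within the scatter of that of compound 1; the step of a 1.3-fold lower number from compound 1 to compound 2 (0.12 log units; within the scatter) does not separate the two, so no order between them is claimed.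

Compound 3, `C#CCSC[C@H](NC(=O)c1cc(O)c(O)c(O)c1)C(=O)OC`, differs from compound 2 by ethynyl in place of but-3-en-1-yl on a saturated chain carbon bound to a sulfur. Among the compounds with values here, the only measured step that bears on this position is the one from compound 1 to compound 2, which also changed the chain on the carbon bound to sulfur and stayed within the scatter. Nothing measured here addresses a triple bond, nor a chain as short as ethynyl. Within the data shown here, with the one relevant step being flat, the expectation for compound 3 is no step beyond the scatter, a 1.2-fold higher number from compound 2 to compound 3 (0.09 log units; within the scatter). Compound 3 is therefore estimated at 48000 nM, with a range from 18000 nM to 130000 nM.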

Compound 3, half-maximal inhibitory concentration: 71500 nM
For compound 3 the middle estimate is 1.5-fold (0.17 log units) below the measured one; the range from low to high includes it.
By their numbers in this assay, from the lowest: compounds 2, 1 and 3 (each within the scatter of the next).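

In this assay, a triple bond on a saturated chain carbon bound to a sulfur now joins the double bonds tested there, and it does not set itself apart from either of them: the change gives a 1.8-fold higher number from compound 2 to compound 3 (0.26 log units; within the scatter) and, against the other alkene chain, a 1.4-fold higher number from compound 1 to compound 3 (0.14 log units; within the scatter). The earlier pair spoke only to a change in the length of an alkene chain, whereas these steps show that the type of unsaturated bond also leaves the three numbers unseparated, so no order can be claimed among the vinyl, but-3-en-1-yl and ethynyl compounds. Nothing available offers an independent measurement that would account for how closely these numbers lie.

What the compounds leave open is whether any group at this place can give a step beyond the scatter, for example an amine, a carboxylic acid or a longer saturated chain. Also open, on these data alone, is whether the same flat picture would hold for these chains if the shared core were changed elsewhere.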